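Nitro substitution on the benzyl-imidazole aromatase series

A few compounds are considered here, and "the series" means these few. Any claim that something is new, unique, unknown or untested is made for them only; others in the source may bear on it.

Compound 1 `O=C(c1ccccc1)c1ccccc1Cn1ccnc1` carries an unsubstituted ring bearing the (1H-imidazol-1-yl)methyl group. Going by the values given here, in an assay on microsomes from placenta for inhibition of Aromatase (Homo sapiens) (on this read-out lower numbers stand for stronger inhibition and higher numbers for weaker inhibition), compound 1 gives 560 nM, the highest number of the two measured so far. Compound 2 `O=C(c1ccccc1)c1cc(Cn2ccnc2)ccc1[N+](=O)[O-]`, a nitro-bearing analogue with the substituents arranged differently on the core, gives in this assay 31 nM, a lower number than compound 1 and beyond the scatter.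

Compound 3 `O=C(c1ccccc1)c1cc([N+](=O)[O-])ccc1Cn1ccnc1` is compound 1 with nitro in place of hydrogen on an aromatic carbon, placed meta to a group of 8 heavy atoms and para to a (1H-imidazol-1-yl)methyl group. Among the compounds with values here, no measured pair shows exactly this change. Because compound 2 gives 31 nM, a nitro group on the core is expected to lower the number, and a step of a 4.7-fold lower number from compound 1 to compound 3 (0.67 log units; beyond the scatter) toward stronger inhibition is expected, smaller than the gap to compound 2 since the arrangement differs. Compound 3 is estimated at 120 nM, within 40 nM to 400 nM.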

Compound 3, half-maximal inhibitory concentration: 25.9 nM
Compound 3: the middle estimate sits 4.6-fold (0.67 log units) above what was measured; measured number outside the range, below it.
By their numbers in this assay, from the lowest: compounds 3 and 2 (each within the scatter of the next); then compound 1.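

In this assay, going by these compounds alone, nitro in place of hydrogen on the aromatic carbon para to the (1H-imidazol-1-yl)methyl group and meta to the group of 8 heavy atoms gives a 22-fold lower number from compound 1 to compound 3 (1.33 log units; beyond the scatter) toward stronger inhibition, the first step that isolates one change. The link between nitro and a lower number can now be tied to this single position on the core of compound 1, rather than read across a different arrangement of the substituents. No measurement at hand accounts for the size of this step.

On these data alone, whether the step is specific to nitro stays open, and an amine, a nitrile or a carboxylic acid on the same carbon would test that. Also open, as far as these compounds go, is whether it depends on this position, which nitro on the other carbons of that ring would settle.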